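Two hydroxyphenyl groups swapped in position on a shared core

A few compounds are considered here, and "the series" means these few. Any claim that something is new, unique, unknown or untested is made for them only; others in the source may bear on it.

Compound 1 `Oc1cccc(-c2cc(-c3ccccc3F)cc(-c3ccccc3O)n2)c1`: 35600 nM
Compound 2 `Oc1cccc(-c2cc(-c3ccccc3C(F)(F)F)cc(-c3ccccc3O)n2)c1`: 7250 nM
Compound 3 `Oc1ccccc1-c1cc(-c2ccccc2OC(F)(F)F)cc(-c2ccccc2O)n1`: 5850 nM

The three compounds were tested in a functional assay on DU-145 cells (Homo sapiens) for inhibition; on this read-out lower numbers stand for stronger inhibition and higher numbers for weaker inhibition. Among them, compound 3 gives the lowest number, 5850 nM. Compound 2 comes closest to it, and its value of 7250 nM is within the usual scatter of that of compound 3, so the two cannot be ranked. Compound 1, with 35600 nM, stands furthest from compound 3, and that gap is beyond the scatter.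

Compound 4 `Oc1cccc(-c2cc(-c3ccccc3OC(F)(F)F)cc(-c3ccccc3O)n2)c1` has not been measured yet. It differs from compound 3 in one place: 3-hydroxyphenyl in place of 2-hydroxyphenyl on an aromatic carbon. The two share the same atoms, joined differently.

Within the data shown here, only one step between measured compounds is available, a 4.9-fold lower number from compound 1 to compound 2 (0.69 log units; beyond the scatter), and it concerns a trifluoromethyl in place of a fluoro, not the change from compound 3 to compound 4. Among the measured compounds shown here, no measured pair shows what moving the hydroxyl from one position of the phenyl to the other does. Compound 4 does, however, carry the same pair of hydroxyphenyl groups as compound 2, which sits close to compound 3 in this assay.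

For the measured compounds named here, with no directly relevant step, compound 4 is expected to fall close to compound 3 in this assay, a change of a 1.1-fold higher number from compound 3 to compound 4 (0.05 log units; within the scatter), estimated at 6500 nM with a range from 2000 nM to 20000 nM.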

Compound 4, half-maximal inhibitory concentration: > 50000 nM
Compound 4: no number, only a limit (the forecaster's own chance of this, stated with the estimate: 5%); middle value at least 7.6-fold (0.88 log units) from the limit.
By their numbers in this assay, from the lowest: compounds 3 and 2 (each within the scatter of the next); then compound 1. At a limit, above all of these: compound 4.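

Swapping 2-hydroxyphenyl for 3-hydroxyphenyl at this place, next to the ring nitrogen, is far from a neutral exchange, even though the two groups have the same atoms and the same hydrogen-bond counts: an at least 8.5-fold higher number from compound 3 to compound 4 (0.93 log units; beyond the scatter). In this assay compound 4 gives only a limit and not a number: the limit of > 50000 nM in this assay, at which 1 of the 4 values shown sits.

With 3-hydroxyphenyl held in place, the group on the other aromatic carbon also matters, as trifluoromethoxy in place of trifluoromethyl gives an at least 6.8-fold higher number from compound 2 to compound 4 (0.83 log units; beyond the scatter), while trifluoromethoxy in place of fluoro gives an at least 1.4-fold higher number from compound 1 to compound 4 (0.14 log units; that floor lies within the scatter), so compound 4 cannot be firmly separated from compound 1.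

The limit leaves open how large the loss from the hydroxyl shift really is, and whether the same shift would matter as much with fluoro or trifluoromethyl on the other aromatic carbon. Also open, going by these compounds, is whether the hydroxyl of the 2-hydroxyphenyl group could be replaced at this place, for instance by an amine or a methoxy group, without the number in this assay rising.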